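Notes on a methyl-for-chloro step in the series

The compounds below may be only part of what the source reports. "The series", "measured", "known", "first", "only" and "open" are said of these compounds alone.

Measured in a functional assay on A549 cells (Homo sapiens) for cytotoxicity; a lower number here means a stronger inhibitor, a higher number a weaker inhibitor:
- compound 1 `Cc1ccc(C2CNC(=O)N2S(=O)(=O)c2ccccc2)cc1`: 157000 nM
- compound 2 `Cc1ccc(C2CNC(=O)N2S(=O)(=O)c2ccc(Cl)cc2)cc1`: 266000 nM

Among the measured compounds shown here, only these two numbers are available so far, and compound 2 lies within the scatter of compound 1, its only neighbour on the scale. The next compound, compound 3 `Cc1ccc(C2CNC(=O)N2S(=O)(=O)c2ccc(C)cc2)cc1`, has not yet been measured. It carries methyl in place of chloro on an aromatic carbon, para to a large group: methyl in place of chloro on an aromatic carbon. The same difference can be read as 4-chlorophenyl to 4-methylphenyl.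

For the measured compounds named here, one measured step bears on this change. Chloro in place of hydrogen on an aromatic carbon gave a 1.7-fold higher number from compound 1 to compound 2 (0.23 log units; within the scatter). That step stays within the scatter. Going by the values given here, no measured compound yet carries methyl at this place, so the data give no direction for the exchange. No step beyond the scatter is therefore expected in this assay. The expected step is a 1.3-fold lower number from compound 2 to compound 3 (0.12 log units; within the scatter). Compound 3 is estimated at 200000 nM, with an expected range of 100000 nM to 400000 nM.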

Compound 3, half-maximal inhibitory concentration: > 302000 nM
Compound 3: no number, only a limit (the forecaster's own chance of this, stated with the estimate: 10%); middle value at least 1.5-fold (0.17 log units) away from the limit.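

For compound 3, this assay returns a limit and not a number: the limit of > 302000 nM in this assay, at which 1 of the 3 values shown sits.

Among the compounds shown here, this gives the first reading with methyl at this place, on an aromatic carbon para to a large group, and the exchange of chloro for methyl can be read only as a floor: an at least 1.1-fold higher number from compound 2 to compound 3 (0.05 log units; that floor lies within the scatter). Against the unsubstituted compound, the floor is an at least 1.9-fold higher number from compound 1 to compound 3 (0.28 log units; that floor lies within the scatter), so neither comparison establishes a step beyond the scatter, and the true size of both remains undetermined. Across compound 1, compound 2 and compound 3, hydrogen, chloro and methyl at this place therefore show no step beyond the scatter toward a lower number, and methyl adds no sign of stronger inhibition to what chloro had shown.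

From the compounds shown here alone, how far compound 3 lies from compound 2 and compound 1 stays open, as the limit gives no end point for either step. Also open, going by these compounds, is whether an amine, a carboxylic acid or a longer chain such as propyl at this place, on the shared core, would give a step beyond the scatter in this assay.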